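Methoxy on the shared core, weighed against a second pair

A few compounds are considered here, and "the series" means these few. Any claim that something is new, unique, unknown or untested is made for them only; others in the source may bear on it.

Three compounds share a styryl-type core carrying a trifluoromethyl group. Compound 1 `FC(F)(F)c1ccc(/C=C\c2cc3ccccc3nc2Cl)cc1` and compound 3 `FC(F)(F)c1cccc(/C=C\c2cc3ccccc3nc2Cl)c1` have the same atoms joined differently; the difference between the two cores is not broken down here. In a functional assay on MDA-MB-468 cells (Homo sapiens) for antiproliferative activity, read by sulforhodamine B assay, with a stated time of 72 h (a higher number here means a weaker inhibitor, a lower number a stronger inhibitor), compound 1 gives 7380 nM, and compound 3 gives 3700 nM. Compound 2 `COc1ccc2nc(Cl)c(/C=C\c3ccc(C(F)(F)F)cc3)cc2c1` differs from compound 1 by methoxy in place of hydrogen on an aromatic carbon; in this assay compound 2 gives 22700 nM, so that a 3.1-fold higher number from compound 1 to compound 2 (0.49 log units; beyond the scatter).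

Compound 4 `COc1ccc2nc(Cl)c(/C=C\c3cccc(C(F)(F)F)c3)cc2c1` has not been measured. Among the measured compounds shown here, it differs from compound 3 by methoxy in place of hydrogen on an aromatic carbon, the same change as the one from compound 1 to compound 2, at a place described in identical terms. For the measured compounds named here, with only one measured pair to rest on, the expectation is that the step from compound 3 to compound 4 will be about as large, because compound 2 showed a 3.1-fold higher number from compound 1 to compound 2 (0.49 log units; beyond the scatter); the estimated step is a 3.0-fold higher number from compound 3 to compound 4 (0.47 log units; beyond the scatter). On that basis compound 4 is expected to give about 11000 nM in this assay, with a likely range from 5000 nM to 28000 nM.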

Compound 4, half-maximal inhibitory concentration: 3910 nM
For compound 4 the middle estimate is 2.8-fold (0.45 log units) above the measured one; measured number outside the range, below it.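

In this assay, methoxy in place of hydrogen on an aromatic carbon gives a 1.1-fold higher number from compound 3 to compound 4 (0.02 log units; within the scatter), so on the core of compound 3 the change has no effect that can be told apart from the scatter. Carried from one core to the other, the same change does not give the same result: the same change on two cores in this assay, a 3.1-fold higher number (0.49 log units; beyond the scatter) from compound 1 to compound 2 and a 1.1-fold higher number (0.02 log units; within the scatter) from compound 3 to compound 4, 2.9-fold (0.46 log units) apart, beyond the scatter of two such steps. Among the compounds shown here, in this series, then, a step measured on the core of compound 1 cannot simply be transferred to the core of compound 3, but with only one pair on each core, this does not show why the two steps differ or whether either would hold for other changes.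

The compounds shown carry only hydrogen or methoxy at this place, so it remains open how fluorine, an amine or a carboxylic acid would behave there on each core. Going by these compounds, it also remains open whether a longer chain, such as ethoxy, would separate the two cores in the same way.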